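Notes on the group at the saturated ring carbon

The compounds below may be only part of what the source reports. "The series", "measured", "known", "first", "only" and "open" are said of these compounds alone.

The three measured compounds share one core and differ only in the group on the saturated ring carbon: compound 1 `Cc1cc(O)c(C2=NN(c3ccc(S(N)(=O)=O)cc3)C(c3ccccc3O)C2)cc1Cl` carries a 2-hydroxyphenyl group, compound 2 `Cc1cc(O)c(C2=NN(c3ccc(S(N)(=O)=O)cc3)C(c3ccccc3Cl)C2)cc1Cl` a 2-chlorophenyl group, and compound 3 `Cc1cc(O)c(C2=NN(c3ccc(S(N)(=O)=O)cc3)C(/C=C/c3ccccc3)C2)cc1Cl` a 2-phenylethenyl group. In a functional assay on SK-OV-3 cells (Homo sapiens) for antiproliferative activity, with a stated time of 48 h (on this read-out higher numbers stand for lower toxicity in this test and lower numbers for higher toxicity in this test), compound 1 gives 38600 nM, compound 2 gives 32300 nM, and compound 3 gives 42700 nM. For the measured compounds named here, compound 3 shows the highest number of the three, but no step separates it from the others beyond the scatter, and the step of a 1.2-fold lower number from compound 1 to compound 2 (0.08 log units; within the scatter) is likewise within the scatter.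

Compound 4 `COc1ccc(C2CC(c3cc(Cl)c(C)cc3O)=NN2c2ccc(S(N)(=O)=O)cc2)cc1OC` has not been measured. Its difference from compound 3: 3,4-dimethoxyphenyl in place of 2-phenylethenyl on a saturated ring carbon. Going by the values given here, the steps that bear on this change are the two earlier exchanges at the same ring carbon, a 1.1-fold higher number from compound 1 to compound 3 (0.04 log units; within the scatter) and a 1.3-fold higher number from compound 2 to compound 3 (0.12 log units; within the scatter), both within the scatter. For compound 4 the expected step is therefore a 1.1-fold lower number from compound 3 to compound 4 (0.03 log units; within the scatter), none beyond the scatter. The estimate for compound 4 in this assay is 40000 nM, with a range from 20000 nM to 80000 nM.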

Compound 4, concentration lethal to 50% of the cells: > 100000 nM
Compound 4: a limit, no number (the forecaster's own chance of this, stated with the estimate: 5%); middle value at least 2.5-fold (0.39 log units) from the limit.
By their numbers in this assay, from the lowest: compounds 2, 1 and 3 (each within the scatter of the next). At a limit, above all of these: compound 4.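

In this assay compound 4 stands at a limit and not at a number: the limit of > 100000 nM in this assay, at which 1 of the 4 values shown sits.

Exchanges at the saturated ring carbon had so far moved nothing beyond the scatter, but 3,4-dimethoxyphenyl does, with an at least 2.3-fold higher number from compound 3 to compound 4 (0.36 log units; beyond the scatter), an at least 3.0-fold higher number from compound 2 to compound 4 (0.49 log units; beyond the scatter) and an at least 2.5-fold higher number from compound 1 to compound 4 (0.41 log units; beyond the scatter). As far as these compounds go, this position therefore responds to the group it carries, towards lower toxicity in this test for this change, and each step is a bound whose full size stays unknown.

The compounds shown do not tell whether the step needs both methoxy groups or only one of them. From the compounds shown here alone, what a phenyl ring with a single methoxy group, or with a dimethylamino group, would give at this carbon also stays open.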